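Oxadiazolylmethyl replacing carbamate on the ring amine nitrogen

The compounds below may be only part of what the source reports. "The series", "measured", "known", "first", "only" and "open" are said of these compounds alone.

Two compounds of the series have numbers in a functional assay on isolated protein for agonist activity at Glucose-dependent insulinotropic receptor (Homo sapiens), read by HTRF and cAMP accumulation; a higher number here means a larger maximal response, a lower number a smaller maximal response. Compound 1 `CC(C)(C)OC(=O)N1CCC(O[C@H]2CC[C@H](Oc3ccc(S(C)(=O)=O)c(F)c3)CC2)CC1` gives 106%. Compound 2 `CC(C)OC(=O)N1CCC(O[C@H]2CC[C@H](Oc3cnc(S(C)(=O)=O)cn3)CC2)CC1` gives 110%, a number within the usual scatter of compound 1, so the two cannot be told apart and neither can be called the larger. Compound 3 `CC(C)c1noc(CN2CCC(O[C@H]3CC[C@H](Oc4cnc(S(C)(=O)=O)cn4)CC3)CC2)n1` has no number yet. Its change from compound 2: (3-isopropyl-1,2,4-oxadiazol-5-yl)methyl in place of isopropoxycarbonyl on an amine nitrogen in a ring. With both measured compounds near a full response, the expected step of a number 8 percentage points lower from compound 2 to compound 3 (within the scatter) is small, none beyond the scatter in either direction. Compound 3 is expected to give 102%, likely between 80% and 120%.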

Compound 3, largest response reached (Emax), in percent of the reference or control that the assay uses: 102%
Estimate against measurement, compound 3: no gap at the digits printed, within the range that was stated.
By their numbers in this assay, from the lowest: compounds 3, 1 and 2 (each within the scatter of the next).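

On the amine nitrogen in a ring, (3-isopropyl-1,2,4-oxadiazol-5-yl)methyl replaces isopropoxycarbonyl with a step in this assay of a number 8 percentage points lower from compound 2 to compound 3 (within the scatter). In this pair, a carbamate on that nitrogen is therefore not required for a near-full maximal response. No measurement at hand accounts for this result.

On these data alone, whether a benzyl group or an isomeric oxadiazole on this nitrogen also keeps the response remains open. Also open, as far as these compounds go, are whether the same replacement holds on the core of compound 1 and whether the two groups differ in potency.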